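Aryl swap on the triazole nitrogen in a weakly active series

The source may report more compounds than this note shows. Statements on the series, on what has been measured and on what is new or still open speak of the compounds shown alone.

Compound 2 `COc1ccccc1-n1nncc1CN1C(=O)C2(C(C#N)=C(N)Oc3c2c2nc4ccccc4nc2c2ccccc32)c2ccccc21` gives in a functional assay on HCT-116 cells (Homo sapiens) for antiproliferative activity, read by MTT assay, with a stated time of 48 h (a higher number here means a weaker inhibitor, a lower number a stronger inhibitor), a value that is only a limit of the assay, > 50000 nM. Compound 1 `COc1ccc(-n2nncc2CN2C(=O)C3(C(C#N)=C(N)Oc4c3c3nc5ccccc5nc3c3ccccc43)c3ccccc32)cc1` likewise returns a limit in this assay, > 50000 nM. Compound 3 `N#CC1=C(N)Oc2c(c3nc4ccccc4nc3c3ccccc23)C12C(=O)N(Cc1cnnn1-c1ccc(N)cc1)c1ccccc12` gives 45200 nM in this assay, and the step from compound 2 to compound 3 is an at least 1.1-fold lower number from compound 2 to compound 3 (0.04 log units; that floor lies within the scatter); the step of an at least 1.1-fold lower number from compound 1 to compound 3 (0.04 log units; that floor lies within the scatter) is of the same kind, while a step that the two limits leave unreadable from compound 1 to compound 2. Two of the three values sit at the limit of > 50000 nM in this assay, at which 2 of the 3 values shown sit.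

Compound 4 `N#CC1=C(N)Oc2c(c3nc4ccccc4nc3c3ccccc23)C12C(=O)N(Cc1cnnn1-c1ccc(Cl)c(Cl)c1)c1ccccc12` differs from compound 2 by 3,4-dichlorophenyl in place of 2-methoxyphenyl on an aromatic nitrogen. Within the data shown here, the only measured change at the same place, the step to compound 3, stays within the scatter, and the other step at that place cannot be read, so no shift beyond the scatter is expected from this change. Compound 4 is therefore expected near the same limit, with an estimated step of a number no higher from compound 2 to compound 4 (the limit leaves the size open) and an estimated value of 50000 nM, between 20000 nM and 100000 nM.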

Compound 4, half-maximal inhibitory concentration: > 50000 nM
Compound 4: only a limit was reported; the forecaster's own chance of this, stated with the estimate: 60%; the middle value sits exactly at the limit.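

In this assay compound 4 returns only a limit, > 50000 nM, which extends the picture at this aromatic nitrogen from methoxy and amino substituents to a phenyl ring carrying two chlorines. Among these compounds, the steps among the compounds reported as limits cannot be read; the one readable step is an at least 1.1-fold higher number from compound 3 to compound 4 (0.04 log units; that floor lies within the scatter), so the data do not separate 3,4-dichlorophenyl from 4-aminophenyl. Changing the substituents on this aryl ring has so far produced no shift beyond the scatter, and most of the series now rests on a single boundary: the limit of > 50000 nM in this assay, at which 3 of the 4 values shown sit.

Open, going by these compounds, is whether a carboxylic acid on this phenyl ring, or a benzyl group or short alkyl chain in place of the aryl group, would give a readable value beyond the scatter. Also open, on these data alone, is whether any change at this position matters more than changes elsewhere on the shared core.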